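A few compounds are considered here, and "the series" means these few. Any claim that something is new, unique, unknown or untested is made for them only; others in the source may bear on it.

In a functional assay on MDA-MB-231 cells (Homo sapiens) for antiproliferative activity, read by sulforhodamine B assay, with a stated time of 72 h (on this read-out lower numbers stand for stronger inhibition and higher numbers for weaker inhibition), compound 1 `O=C(/C=C/c1csc2ccccc12)c1cc(F)ccc1O` gives 8400 nM and compound 2 `Cc1ccc(O)c(C(=O)/C=C/c2csc3ccccc23)c1` gives 6000 nM. Among the compounds with values here, compound 2 stands level with compound 1, the only other measured compound. The two numbers lie within the usual scatter of each other. Compound 3 `COc1ccc(O)c(C(=O)/C=C/c2csc3ccccc23)c1` keeps the shared core and alters a single group: methoxy in place of methyl on an aromatic carbon. This is methoxy in place of methyl on an aromatic carbon, para to a hydroxy group. Within the data shown here, only one measured step bears on this change, a swap at the same place, methyl in place of fluoro: a 1.4-fold lower number from compound 1 to compound 2 (0.15 log units; within the scatter). A single small step is thin evidence, and it says nothing directly about methoxy. Among the measured compounds shown here, with that step as the only guide, no change beyond the scatter is expected in this assay. The estimated change is a 1.2-fold lower number from compound 2 to compound 3 (0.08 log units; within the scatter). For compound 3, the expected value is 5000 nM, with an estimated range of 1800 nM to 12000 nM.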

Compound 3, half-maximal inhibitory concentration: 760 nM
Compound 3: the middle estimate sits 6.6-fold (0.82 log units) above what was measured; the measured number lies below the stated range.
By their numbers in this assay, from the lowest: compound 3; then compounds 2 and 1 (each within the scatter of the next).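

In this assay, within the data shown here, this position proves far more sensitive than the earlier compounds suggested: methoxy in place of methyl gives a 7.9-fold lower number from compound 2 to compound 3 (0.90 log units; beyond the scatter) and methoxy in place of fluoro gives an 11-fold lower number from compound 1 to compound 3 (1.04 log units; beyond the scatter) in the same direction. The swap between fluoro and methyl had stayed within the scatter, so the large drop appears only with methoxy, which brings an oxygen and a hydrogen-bond acceptor to this carbon, para to a hydroxy group. No measurement shown here accounts for the drop.

From the compounds shown here alone, whether the oxygen or the larger size of the group matters remains open, and an amine or an ethoxy group at this carbon would help to tell these apart. Also open, going by these compounds, is whether a longer chain on the oxygen would lower the number further or raise it again.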